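This account rests on a few compounds, and the source may have more. Where it says the series, first, only, none or still open, it means among the compounds named here.

Measured compounds, with their values in a functional assay on PC-3 cells (Homo sapiens) for cytotoxicity, read by MTT assay, with a stated time of 48 h; a higher number here means a weaker inhibitor, a lower number a stronger inhibitor:

Compound 1, `CC1=NN(C(=O)CN2CCCC2)C(c2ccccc2O)C1`: compound 1 gives 6670 nM.
Compound 2, `CC[N+](C)(CC)CC(=O)N1N=C(C)CC1c1ccccc1OC`: compound 2 gives 4170 nM.
Compound 3, `O=C(c1ccccc1)N1N=C(c2cc3ccccc3oc2=O)CC1c1ccccc1`: compound 3 gives 5870 nM.

Among these three numbers, compound 3 holds the second highest place. Its nearest neighbour is compound 1, whose number is a little higher, and its furthest is compound 2, whose number is somewhat lower; both of these gaps fall within the scatter of repeated measurements, so nothing can be said about an order among the three. No two of the measured compounds differ in only one place, so no single-step comparison is available from the measured set.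

Compound 4, `O=C(c1ccccc1Cl)N1N=C(c2cc3ccccc3oc2=O)CC1c1ccccc1`, has not yet been measured in this assay. It differs from compound 3 by chloro in place of hydrogen on an aromatic carbon. Within the data shown here, the change amounts to one heavy atom entering with no donor or acceptor and no charge, and there is no measured pair in this set that shows what such a change does. For that reason the expectation is a step of no size beyond the scatter, and the step from compound 3 to compound 4 is estimated as a 1.2-fold lower number from compound 3 to compound 4 (0.07 log units; within the scatter). Compound 4 is accordingly expected to give about 5000 nM, with a range from 1800 nM to 14000 nM, close to the number of compound 3.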

Compound 4, half-maximal inhibitory concentration: 6370 nM
Estimate against measurement, compound 4: 1.3-fold (0.11 log units) below, and the stated range covers the measured number.
By their numbers in this assay, from the lowest: compounds 2, 3, 4 and 1 (each within the scatter of the next).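

The pair gives this set its first comparison that differs in only one place: in this assay, chloro taking the place of hydrogen on an aromatic carbon, ortho to a large group, turns benzoyl into (2-chlorophenyl)carbonyl and gives a 1.1-fold higher number from compound 3 to compound 4 (0.04 log units; within the scatter). Among these compounds, at this place, then, the entry of a single chlorine does not separate compound 4 from compound 3, something the earlier compounds, none of them linked by a single change, could not show. No measurement at hand accounts for this outcome or says how the change acts.

As far as these compounds go, whether a different group at this same place, such as a methoxy, an amine or a carboxylic acid, would produce a step beyond the scatter remains open. Also open, from the compounds shown here alone, is whether chloro on another carbon of this ring, or on the other carbon-only aromatic ring of compound 3, would behave as it does here.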